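Moving a chlorine on a phenyl ring: does the core matter?

This account rests on a few compounds, and the source may have more. Where it says the series, first, only, none or still open, it means among the compounds named here.

In a functional assay on HCT-15 cells (Homo sapiens) for cytotoxicity, read by ELISA, with a stated time of 4 days (a higher number here means a weaker inhibitor, a lower number a stronger inhibitor), compound 1 `Clc1cccc(-c2cc(-c3ccoc3)cc(-c3ccc(Cl)s3)n2)c1` gives 950 nM. Compound 2 `Clc1ccc(-c2cc(-c3ccoc3)cc(-c3ccc(Cl)s3)n2)cc1` differs by 4-chlorophenyl in place of 3-chlorophenyl on an aromatic carbon and gives 640 nM, so that a 1.5-fold lower number from compound 1 to compound 2 (0.17 log units; within the scatter), a step within the scatter.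

Compound 3 `Cc1ccsc1-c1cc(-c2ccc(Cl)o2)cc(-c2cccc(Cl)c2)n1` is built on a different core; the difference between the two cores is not broken down here. In this assay compound 3 gives 26400 nM, the highest of the three numbers.

Compound 4 `Cc1ccsc1-c1cc(-c2ccc(Cl)o2)cc(-c2ccc(Cl)cc2)n1` has not been measured. It differs from compound 3 by 4-chlorophenyl in place of 3-chlorophenyl on an aromatic carbon. This is the same kind of change as from compound 1 to compound 2, though the surroundings differ: in compound 3 the place is meta to a 3-methylthiophen-2-yl group and meta to a 5-chlorofuran-2-yl group, whereas in compound 1 it is meta to a 5-chlorothiophen-2-yl group and meta to a furan-3-yl group.

Because the same change gave a 1.5-fold lower number from compound 1 to compound 2 (0.17 log units; within the scatter), a similarly small step is expected, a 1.3-fold lower number from compound 3 to compound 4 (0.12 log units; within the scatter). Compound 4 is therefore estimated at 20000 nM, expected within 7000 nM to 60000 nM.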

Compound 4, half-maximal inhibitory concentration: 30300 nM
Compound 4: the middle estimate sits 1.5-fold (0.18 log units) below what was measured; measured number inside the range.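

In this assay, putting 4-chlorophenyl in place of 3-chlorophenyl on the second core gives a 1.1-fold higher number from compound 3 to compound 4 (0.06 log units; within the scatter), so on this core the move of the chlorine leaves no measurable mark. Set beside the earlier step, the change looks the same on both cores: the same change on two cores in this assay, a 1.5-fold lower number (0.17 log units; within the scatter) from compound 1 to compound 2 and a 1.1-fold higher number (0.06 log units; within the scatter) from compound 3 to compound 4, 1.7-fold (0.23 log units) apart, within the scatter of two such steps. This supports carrying the change from one of these cores to the other with little expected effect, but it rests on a single pair per core in one assay, both with steps too small to read, and it does not show that the change would stay this small on other cores or what the differences between the two cores contribute.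

The compounds shown leave open whether a different group in place of the chlorine, such as a methoxy, an amine or a carboxylic acid, would give a step beyond the scatter. They also leave open which of the groups that differ between the cores, such as the 3-methylthiophen-2-yl group or the 5-chlorofuran-2-yl group, matters most.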